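Enlarging the side chain of compound 3

This account rests on a few compounds, and the source may have more. Where it says the series, first, only, none or still open, it means among the compounds named here.

Measured so far:
compound 1 (`CN(C)CCNc1nc(-c2ccc(Cl)cc2)nc2ccccc12`) gives 60000 nM
compound 2 (`COc1ccc(-c2nc(NCCCN(C)C)c3ccccc3n2)cc1`) gives 67500 nM
compound 3 (`COc1cc(-c2nc(NCCN(C)C)c3ccccc3n2)cc(OC)c1OC`) gives 50000 nM

All three values come from a toxicity assay on cells (Macrophage, Homo sapiens) for inhibition, read by MTT assay (on this read-out higher numbers stand for weaker inhibition and lower numbers for stronger inhibition), and should be read together. Compound 3 (50000 nM) stands within the usual scatter of both compound 1 and compound 2, so the three cannot be ranked.

Compound 4 (`COc1cc(-c2nc(NCCCN3CCN(C)CC3)c3ccccc3n2)cc(OC)c1OC`) has not yet been measured. Compared with compound 3, it carries (4-methylpiperazin-1-yl)methyl in place of dimethylamino, on a saturated chain carbon, two bonds along the chain from a nitrogen on an aromatic ring ((4-methylpiperazin-1-yl)methyl in place of dimethylamino on a saturated chain carbon, two bonds along the chain from a nitrogen on an aromatic ring).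

No two measured compounds differ in one place only, so the size of this change has not been shown directly. Compound 2 (67500 nM) and compound 3 (50000 nM) have different side chains, yet their values lie within the scatter. No step beyond the scatter is therefore expected in this assay. The estimated change is a 1.3-fold lower number from compound 3 to compound 4 (0.10 log units; within the scatter) (expected to stay within the scatter). For compound 4 the expected value is 40000 nM (estimated range 15000 nM to 90000 nM).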

Compound 4, half-maximal inhibitory concentration: 54000 nM
Beside the measured number, compound 4's estimate is 1.4-fold (0.13 log units) below it; the measured number falls inside the stated range.
By their numbers in this assay, from the lowest: compounds 3, 4, 1 and 2 (each within the scatter of the next).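

Among the compounds shown here, this is the first pair here that differs in one place only, so a change on this side chain can now be read directly: in this assay, (4-methylpiperazin-1-yl)methyl in place of dimethylamino, on a saturated chain carbon, two bonds along the chain from a nitrogen on an aromatic ring, gives a 1.1-fold higher number from compound 3 to compound 4 (0.03 log units; within the scatter). A much larger group with a six-membered non-aromatic ring thus leaves the number within the scatter at this position. Nothing on hand speaks to why the two compounds read alike.

As far as these compounds go, whether a different end group, such as a carboxylic acid or a morpholine ring, would also stay within the scatter remains open. Also open, from the compounds shown here alone, is what a 3-(dimethylamino)propyl chain would give on this core, as chain length and ring change together in this step.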